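Replacing the 4-nitrophenyl in compound 1

This account rests on a few compounds, and the source may have more. Where it says the series, first, only, none or still open, it means among the compounds named here.

Measured so far in a functional assay on HepG2 cells (Homo sapiens) for cytotoxicity, read by MTT assay, with a stated time of 48 h; on this read-out lower numbers stand for stronger inhibition and higher numbers for weaker inhibition:
compound 1 `O=c1cc(-c2ccc([N+](=O)[O-])cc2)oc2c(CN3CCCCC3)cc(Cl)cc12` gives 8910 nM
compound 2 `CN(C)Cc1cc(Cl)cc2c(=O)cc(-c3ccc([N+](=O)[O-])cc3)oc12` gives 6190 nM

These two numbers lie within the scatter of each other, so compound 1 holds no clear rank. Going by the values given here, the only measured step is a 1.4-fold lower number from compound 1 to compound 2 (0.16 log units; within the scatter) and it concerns the amine on the chain, not the aryl group.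

Compound 3 `O=c1cc(-c2ccccc2Cl)oc2c(CN3CCCCC3)cc(Cl)cc12` carries a different change, with 2-chlorophenyl in place of 4-nitrophenyl on an aromatic carbon next to the ring oxygen: 2-chlorophenyl in place of 4-nitrophenyl on an aromatic carbon. Among the compounds with values here, no measured step covers a change at this place, so the amine step gives no size for it. Within the data shown here, it shows only that one change elsewhere on the core of compound 1 stayed within the scatter.

With no measured guide, the expectation starts from compound 1 at 8910 nM and assumes no step beyond the scatter in either direction, with wide uncertainty. The expected change is a 1.0-fold higher number from compound 1 to compound 3 (0.00 log units; within the scatter) in this assay overall. The estimate for compound 3 is 9000 nM, within an expected range from 3000 nM to 27000 nM as its ends.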

Compound 3, half-maximal inhibitory concentration: 10700 nM
Compound 3: the middle estimate sits 1.2-fold (0.08 log units) below what was measured; low and high end bracket the measured number.
By their numbers in this assay, from the lowest: compounds 2, 1 and 3 (each within the scatter of the next).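

In this assay, 2-chlorophenyl in place of 4-nitrophenyl on the aromatic carbon next to the ring oxygen gives a 1.2-fold higher number from compound 1 to compound 3 (0.08 log units; within the scatter). Going by these compounds alone, this is the first measured step at this position, since the earlier pair differed only in the amine on the chain, and it shows that a full exchange of the aryl group, with 2 hydrogen-bond acceptors leaving and 0 entering, can stay within the scatter on the core of compound 1. Alongside a 1.4-fold lower number from compound 1 to compound 2 (0.16 log units; within the scatter), it means that neither of the two single changes measured from compound 1 has moved the number beyond the scatter, and nothing at hand offers an explanation for this result.

Because of the single exchange, the compounds shown leave open whether the chlorine, the nitro group or the place of each on the phenyl ring matters on its own, as the step alters the substituent and its place on the ring together. They also leave open whether a plain phenyl, an aminophenyl or a carboxyphenyl at this position would give a number beyond the scatter from compound 1.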